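The source may report more compounds than this note shows. Statements on the series, on what has been measured and on what is new or still open speak of the compounds shown alone.

Compound 1, `COc1cc(Oc2cccc(Nc3ccccc3)c2)cc(OC)c1CNCc1ccc(Br)cc1`: 5410 nM
Compound 2, `COc1cc(Oc2cccc(Nc3ccccc3)c2)cc(OC)c1CNCCNC(C)=O`: 5090 nM
Compound 3, `COc1ccc([C@@H](C)NCc2c(OC)cc(Oc3cccc(Nc4ccccc4)c3)c(OC)c2OC)cc1`: 4690 nM

All three were tested in a functional assay on HCT-15 cells (Homo sapiens) for inhibition, read by MTT assay, with a stated time of 72 h; on this read-out higher numbers stand for weaker inhibition and lower numbers for stronger inhibition. Compound 2 gives the second highest of the three numbers; its nearest neighbour is compound 1, and its furthest is compound 3, yet both of those gaps lie within the scatter, so the three compounds cannot be told apart on these data.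

The next compound, compound 4, `COc1cc(Oc2cccc(Nc3ccccc3)c2)cc(OC)c1CCO`, differs from compound 2 in one place: hydroxymethyl in place of (2-acetamidoethyl)amino on a saturated chain carbon bound to an aromatic carbon. The whole (2-acetamidoethyl)amino group, with its amine and its amide, is gone, and only a hydroxymethyl remains on the saturated chain carbon bound to an aromatic carbon.

Among the compounds with values here, only one measured step touches this part of the molecule: a 1.1-fold lower number from compound 1 to compound 2 (0.03 log units; within the scatter). That step swapped one substituent on the amine nitrogen for another and left the amine itself in place, and it made no difference beyond the scatter. Within the data shown here, the step to compound 4 is different in kind, since it removes the amine altogether, and no measured pair shows what that does. The expectation for compound 4 is therefore a number close to that of compound 2, with the step of a 1.3-fold higher number from compound 2 to compound 4 (0.11 log units; within the scatter) estimated as small and the uncertainty wide. Compound 4 is estimated at 6500 nM, within the range 2500 nM to 18000 nM.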

Compound 4, half-maximal inhibitory concentration: 12100 nM
For compound 4 the middle estimate is 1.9-fold (0.27 log units) below the measured one; low and high end bracket the measured number.
By their numbers in this assay, from the lowest: compounds 3, 2 and 1 (each within the scatter of the next); then compound 4.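

In this assay, the earlier step on the amine nitrogen stayed within the scatter, but removing the amine does register: replacing (2-acetamidoethyl)amino with hydroxymethyl gives a 2.4-fold higher number from compound 2 to compound 4 (0.38 log units; beyond the scatter) and replacing (4-bromobenzyl)amino with hydroxymethyl gives a 2.2-fold higher number from compound 1 to compound 4 (0.35 log units; beyond the scatter) in a modest shift toward weaker inhibition. Two very different groups, one carrying an amide and the other an aromatic ring with bromine, therefore read alike, and both give stronger inhibition than the hydroxymethyl of compound 4, so at this position the change that shows up so far is the loss of the whole amine-bearing group rather than a swap of what sits on its nitrogen. Nothing measured here explains this shift.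

Compound 4 loses the amine nitrogen and its substituent in a single change, so the compounds shown cannot separate the contribution of the nitrogen from that of the group attached to it. They also leave open how a plain primary amine or a carboxylic acid would read on a saturated chain carbon bound to an aromatic carbon, and either would show whether the shift is tied to the amine or simply to the hydroxymethyl that replaced it.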